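A few compounds are considered here, and "the series" means these few. Any claim that something is new, unique, unknown or untested is made for them only; others in the source may bear on it.

For the measured compounds named here, in a functional assay on a cell-free system (plasma, Homo sapiens) for inhibition, with Plasma (Rattus norvegicus) as the target (a higher number here means a weaker inhibitor, a lower number a stronger inhibitor), compound 2 `CCCOc1ccc2c(N3CCNCC3)cc(=O)oc2c1C` gives 2950 nM, within the scatter of compound 1 `Cc1c(OCc2ccccc2)ccc2c(N3CCNCC3)cc(=O)oc12` at 1900 nM, the only other value. Compound 3 `CCCCOc1ccc2c(N3CCNCC3)cc(=O)oc2c1C` differs from compound 2 by methyl in place of hydrogen on a saturated chain carbon, three bonds along the chain from an oxygen on an aromatic ring, which reads as propyl to butyl. Going by the values given here, the only measured step that bears on this is a 1.6-fold higher number from compound 1 to compound 2 (0.19 log units; within the scatter), and it is a larger change of group than the one here. With that step inside the scatter, no step beyond the scatter is expected in this assay. Compound 3 is expected at 2500 nM, with an estimated range of 1200 nM to 5200 nM. The expected step is a 1.2-fold lower number from compound 2 to compound 3 (0.07 log units; within the scatter).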

Compound 3, half-maximal inhibitory concentration: 2790 nM
Estimate against measurement, compound 3: 1.1-fold (0.05 log units) below, within the range that was stated.
By their numbers in this assay, from the lowest: compounds 1, 3 and 2 (each within the scatter of the next).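

In this assay, methyl in place of hydrogen on a saturated chain carbon, three bonds along the chain from an oxygen on an aromatic ring, gives a 1.1-fold lower number from compound 2 to compound 3 (0.02 log units; within the scatter), so propyl to butyl leaves the number inside the scatter. The remaining comparison gives a 1.5-fold higher number from compound 1 to compound 3 (0.17 log units; within the scatter), so all three compounds remain within the scatter of one another. No available evidence bears on the reason for this.

On these data alone, whether a longer chain, an amine or a carboxylic acid on this chain would give a step beyond the scatter remains open.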